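This account rests on a few compounds, and the source may have more. Where it says the series, first, only, none or still open, it means among the compounds named here.

Measured compounds:
- Compound 1, `COc1cc(-c2cc(/C=C/C(=O)c3ccc(Cl)c(Cl)c3)[nH]n2)cc(OC)c1OC`: 94%
- Compound 2, `COc1ccc(C(=O)/C=C/c2cc(-c3cc(OC)c(OC)c(OC)c3)n[nH]2)cc1OC`: 95%
- Compound 3, `COc1ccc(C(=O)/C=C/c2cc(-c3cc(OC)c(OC)c(OC)c3)n[nH]2)cc1`: 99%

The three compounds share one core and differ only in the aryl group on the carbonyl carbon. In a functional assay on MDA-MB-435 cells (Homo sapiens) for cytotoxicity, read by sulforhodamine B assay, with a stated time of 48 h, tested at 0.01 uM (on this read-out higher numbers stand for a weaker effect at the one concentration tested and lower numbers for a stronger effect), compound 3 gives 99%, the highest of the three numbers, yet its gaps to the other two are both within the scatter, so no ordering among them can be read. The steps of a number 1 percentage points higher from compound 1 to compound 2 (within the scatter) and a number 5 percentage points higher from compound 1 to compound 3 (within the scatter) both exchange the aryl group on the carbonyl carbon, and a number 4 percentage points higher from compound 2 to compound 3 (within the scatter) removes one methoxy group; none of them moves the read-out beyond the scatter.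

Compound 4, `COc1cc(-c2cc(/C=C/C(=O)c3ccc(F)c(F)c3)[nH]n2)cc(OC)c1OC`, is the next member. Its difference from compound 3: 3,4-difluorophenyl in place of 4-methoxyphenyl on a carbonyl carbon. This is the same kind of exchange at the carbonyl carbon as in the two steps from compound 1, which were both within the scatter. Compound 4 is therefore expected to show no step beyond the scatter in this assay, a step of about a number 3 percentage points lower from compound 3 to compound 4 (within the scatter). Compound 4 is estimated at 96%, within 86% to 104%.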

Compound 4, a percentage reported as activity, at one concentration (the size of the read-out at that concentration, not a potency): 98%
Compound 4: the middle estimate sits 2 percentage points below what was measured; low and high end bracket the measured number.
By their numbers in this assay, from the lowest: compounds 1, 2, 4 and 3 (each within the scatter of the next).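

With 3,4-difluorophenyl on the carbonyl carbon, this assay records a number 1 percentage points lower from compound 3 to compound 4 (within the scatter) against 4-methoxyphenyl and a number 3 percentage points higher from compound 2 to compound 4 (within the scatter) against 3,4-dimethoxyphenyl and a number 4 percentage points higher from compound 1 to compound 4 (within the scatter) against 3,4-dichlorophenyl. Fluorine substituents thus join the chlorine and methoxy substituents already seen on this aryl group, and the fourth aryl group does not separate from the other three, so all four compounds lie within the scatter of each other at this one concentration. Nothing available bears on why this exchange leaves the read-out inside the scatter. The compounds shown leave open whether these aryl groups would differ at any other concentration. They also leave open whether an amine or a carboxylic acid on this aryl group, or a longer chain in its place on the carbonyl carbon, would move the read-out beyond the scatter.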